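Chloro on the phenyl ring across two related cores

A few compounds are considered here, and "the series" means these few. Any claim that something is new, unique, unknown or untested is made for them only; others in the source may bear on it.

Measured so far: compound 1 `O=C1C2CCCN2C(=O)N1CN1CCN(c2ccccc2)CC1` gives 1000 nM in an assay on isolated protein for binding affinity to Adrenergic receptor alpha-1 (Rattus norvegicus), read by radioligand binding; a higher number here means a weaker inhibitor, a lower number a stronger inhibitor; compound 2 `O=C1C2CCCN2C(=O)N1CN1CCN(c2cccc(Cl)c2)CC1` gives 292 nM. Compound 3 `O=C1C2CCCCN2C(=O)N1CCN1CCN(c2ccccc2)CC1` gives only a limit of the assay, > 1000 nM.

From compound 1 to compound 2 the change is chloro in place of hydrogen on an aromatic carbon, and the step was a 3.4-fold lower number from compound 1 to compound 2 (0.53 log units; beyond the scatter). Compound 3 carries a different core; the difference between the two cores is not broken down here. Compound 4 `O=C1C2CCCCN2C(=O)N1CCN1CCN(c2cccc(Cl)c2)CC1` is not yet measured; it differs from compound 3 by chloro in place of hydrogen on an aromatic carbon, the same change as between compound 1 and compound 2. As far as these compounds go, since compound 3 sits at the limit of > 1000 nM in this assay, at which 1 of the 3 values shown sits, the starting point is unknown, so the expected step from compound 3 to compound 4 is estimated as a step that the limit leaves unreadable from compound 3 to compound 4. Compound 4 is expected to fall near 1200 nM, between 300 nM and 5000 nM.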

Compound 4, inhibition constant: 375 nM
Compound 4: middle estimate off by 3.2-fold (0.51 log units), on the high side, and the stated range covers the measured number.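

The change from phenyl to 3-chlorophenyl gave an at least 2.6-fold lower number from compound 3 to compound 4 (0.42 log units; beyond the scatter) in this assay, the same direction as a 3.4-fold lower number from compound 1 to compound 2 (0.53 log units; beyond the scatter) on the other core. Compound 3 gives only a limit of the assay, > 1000 nM, so the second step has a floor but no exact size. The change therefore carried over in direction to a second core, but whether it carried over in size stays unresolved: the same change on two cores in this assay, a 3.4-fold lower number (0.53 log units; beyond the scatter) from compound 1 to compound 2 and an at least 2.6-fold lower number (0.42 log units; beyond the scatter) from compound 3 to compound 4; the limit leaves it open whether they differ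

The compounds shown leave open how a methoxy or a trifluoromethyl group at the same place would compare with chloro on either core. They also leave open whether the chloro step would hold with a longer chain linking the core to the rest of the molecule.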